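The source may report more compounds than this note shows. Statements on the series, on what has been measured and on what is new or still open speak of the compounds shown alone.

In a functional assay on PC-3 cells (Homo sapiens) for cytotoxicity, read by MTT assay, with a stated time of 72 h (a lower number here means a stronger inhibitor, a higher number a weaker inhibitor), compound 2, `O=C(Nc1nc2ccc(Cl)cc2s1)c1cn(-c2ccccc2)nc1-c1ccccc1`, gives 3690 nM, the lowest of the three numbers: compound 1, `O=C(Nc1nc2ccccc2s1)c1cn(-c2ccccc2)nc1-c1ccccc1`, gives 10400 nM, and compound 3, `COc1ccc2nc(NC(=O)c3cn(-c4ccccc4)nc3-c3ccccc3)sc2c1`, gives 17500 nM, so that a 2.8-fold lower number from compound 1 to compound 2 (0.45 log units; beyond the scatter) and a 4.7-fold higher number from compound 2 to compound 3 (0.68 log units; beyond the scatter). Compound 4, `COc1ccc(-c2nn(-c3ccccc3)cc2C(=O)Nc2nc3ccc(Cl)cc3s2)cc1`, differs from compound 2 by methoxy in place of hydrogen on an aromatic carbon. Among the measured compounds shown here, the one measured methoxy step on a different ring, a 1.7-fold higher number from compound 1 to compound 3 (0.23 log units; within the scatter), stayed within the scatter, and no measured step touches the ring changed here. Compound 4 is therefore expected to stay close to compound 2, with at most a small weakening, a 1.5-fold higher number from compound 2 to compound 4 (0.17 log units; within the scatter). The estimate for compound 4 in this assay is 5500 nM, between 2000 nM and 15000 nM.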

Compound 4, half-maximal inhibitory concentration: 6510 nM
For compound 4 the middle estimate is 1.2-fold (0.07 log units) below the measured one; low and high end bracket the measured number.
By their numbers in this assay, from the lowest: compounds 2, 4, 1 and 3 (each within the scatter of the next, the first and the last beyond it).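

In this assay, the change from phenyl to 4-methoxyphenyl gives the first step read at this ring, and it stays within the scatter: a 1.8-fold higher number from compound 2 to compound 4 (0.25 log units; within the scatter). Methoxy para to a large group thus leaves compound 4 not separated from compound 2. The step also matches the methoxy step read on a different ring: the same change on two cores in this assay, a 1.7-fold higher number (0.23 log units; within the scatter) from compound 1 to compound 3 and a 1.8-fold higher number (0.25 log units; within the scatter) from compound 2 to compound 4, 1.0-fold (0.02 log units) apart, within the scatter of two such steps

The compounds shown hold only hydrogen and methoxy at this place, so it remains open whether an amine, a carboxylic acid or a longer chain there would move the number beyond the scatter. On these data alone, it also remains open how 4-methoxyphenyl behaves on the core of compound 1, without the chloro.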